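Changing the Halogenated Ring on a Methylated Core

This account rests on a few compounds, and the source may have more. Where it says the series, first, only, none or still open, it means among the compounds named here.

Measured in a functional assay on HepG2 cells (Homo sapiens) for cytotoxicity, read by MTT assay, with a stated time of 72 h; on this read-out higher numbers stand for weaker inhibition and lower numbers for stronger inhibition:
Compound 1, `O=C(Nc1ccc(Oc2ccnc3[nH]ccc23)cc1)c1nn(-c2ccc(Br)cc2)ccc1=O`, gives 4280 nM.
Compound 2, `O=C(Nc1ccc(Oc2ccnc3[nH]ccc23)cc1)c1nn(-c2ccc(Cl)c(F)c2)ccc1=O`, gives 5240 nM.
Compound 3, `Cn1ccc2c(Oc3ccc(NC(=O)c4nn(-c5ccc(Br)cc5)ccc4=O)cc3)ccnc21`, gives 39200 nM.

Compound 3 stands highest of the three numbers, meaning the weakest inhibition of cell growth; its gaps to compound 2 and to compound 1 are both beyond the scatter. For the measured compounds named here, its only difference from compound 1 is a methyl in place of hydrogen on an aromatic nitrogen, and that step was a 9.2-fold higher number from compound 1 to compound 3 (0.96 log units; beyond the scatter). Compound 4, `Cn1ccc2c(Oc3ccc(NC(=O)c4nn(-c5ccc(Cl)c(F)c5)ccc4=O)cc3)ccnc21`, keeps that methyl and alters the other ring: 4-chloro-3-fluorophenyl in place of 4-bromophenyl on an aromatic nitrogen. The same exchange has been seen once before, on the core without the methyl, where a 1.2-fold higher number from compound 1 to compound 2 (0.09 log units; within the scatter). That step fell within the scatter, so it gives no clear direction. Compound 4 is therefore expected to show only a small step, if any, toward a higher number: a 1.1-fold higher number from compound 3 to compound 4 (0.06 log units; within the scatter). The estimate for compound 4 in this assay is 45000 nM, with a range from 15000 nM to 130000 nM.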

Compound 4, half-maximal inhibitory concentration: > 60000 nM
Compound 4: a limit, no number; the forecaster's own chance of this, stated with the estimate: 15%; middle value at least 1.3-fold (0.12 log units) away from the limit.
By their numbers in this assay, from the lowest: compounds 1 and 2 (each within the scatter of the next); then compound 3. At a limit, above all of these: compound 4.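

In this assay, compound 4 reaches a limit of the assay, > 60000 nM, and this is not a number. The halogen exchange on the methylated core gives an at least 1.5-fold higher number from compound 3 to compound 4 (0.18 log units; that floor lies within the scatter), so the exchange may be as small here as on the core without the methyl, or it may be larger: the same change on two cores in this assay, a 1.2-fold higher number (0.09 log units; within the scatter) from compound 1 to compound 2 and an at least 1.5-fold higher number (0.18 log units; that floor lies within the scatter) from compound 3 to compound 4; the limit leaves it open whether they differ The methyl on the aromatic nitrogen now raises the number with a second halogenated ring as well, an at least 11-fold higher number from compound 2 to compound 4 (1.05 log units; beyond the scatter), so both pairs that carry this change point the same way: the same change on two cores in this assay, a 9.2-fold higher number (0.96 log units; beyond the scatter) from compound 1 to compound 3 and an at least 11-fold higher number (1.05 log units; beyond the scatter) from compound 2 to compound 4; the limit leaves it open whether they differ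

Going by these compounds, the true size of the step to compound 4 stays open. Also open, on these data alone, is how an ethyl group on that aromatic nitrogen, or a phenyl ring carrying a methoxy group in place of the halogens, would read in this assay.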